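Swapping the aromatic group of compound 3

This account rests on a few compounds, and the source may have more. Where it says the series, first, only, none or still open, it means among the compounds named here.

- compound 1 `CSc1ncnc2c1c(-c1cccs1)cn2[C@@H]1O[C@H](CO)[C@@H](O)[C@H]1O` gives > 20000 nM (a limit)
- compound 2 `Cc1ncnc2c1c(-c1cc3ccccc3o1)cn2[C@@H]1O[C@H](CO)[C@@H](O)[C@H]1O` gives 17300 nM
- compound 3 `Cc1nc(N)c2c(-c3ccoc3)cn([C@@H]3O[C@H](CO)[C@@H](O)[C@H]3O)c2n1` gives > 100000 nM (a limit)

All three values come from a functional assay on CCRF-CEM cells (Homo sapiens), read by MTT assay, with a stated time of 72 h (a lower number here means a stronger inhibitor, a higher number a weaker inhibitor), and only compound 2 has a number. Compound 3 stands at a limit, > 100000 nM, and not at a number. Compound 1 also has only a limit, > 20000 nM, in this set. Compound 4 `Cc1nc(N)c2c(-c3cc4ccccc4o3)cn([C@@H]3O[C@H](CO)[C@@H](O)[C@H]3O)c2n1`, not yet measured, has 1-benzofuran-2-yl in place of furan-3-yl on an aromatic carbon and keeps the rest of compound 3.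

Going by the values given here, no measured pair isolates this change. Compound 2 carries 1-benzofuran-2-yl on a different core and gives 17300 nM in this assay, so a stronger inhibitor is expected. The expected step of an at least 6.6-fold lower number from compound 3 to compound 4 (0.82 log units; beyond the scatter) is estimated to exceed the scatter. Compound 4 is estimated at 15000 nM, within 3000 nM to 70000 nM as its expected range.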

Compound 4, half-maximal inhibitory concentration: > 20000 nM
Compound 4 ended at the assay's limit (the forecaster's own chance of this, stated with the estimate: 35%); at least 1.3-fold (0.12 log units) between middle value and limit.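

Going by these compounds alone, compound 3 and compound 4 both stand at limits, and no step between them can be read. The compounds shown leave open whether 1-benzofuran-2-yl in place of furan-3-yl changes inhibition on this core at all.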